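The source may hold more compounds than are shown below. What is called first, only, known or untested is meant among the compounds shown, and "the series" means these compounds.

Measured compounds and their values:
compound 1, `CC[C@H](CCn1cncn1)c1ccccc1`: 99.8 ug/mL
compound 2, `CC[C@H](CCn1cncn1)c1ccc(Cl)cc1`: 57 ug/mL
compound 3, `CCCC[C@H](CCn1cncn1)c1ccccc1`: 48.3 ug/mL

These numbers come from an ADME assay on RD cells (Homo sapiens) for cytotoxicity, read by MTT assay, with a stated time of 3 days; on this read-out higher numbers stand for lower toxicity in this test and lower numbers for higher toxicity in this test. Among the three, compound 3 has the lowest number; its value lies close to that of compound 2, within the usual scatter, while the gap to compound 1 is larger: a 2.1-fold lower number from compound 1 to compound 3 (0.32 log units; beyond the scatter).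

Compound 4, `CCCC[C@H](CCn1cncn1)c1ccc(Cl)cc1`, differs from compound 3 in one place: chloro in place of hydrogen on an aromatic carbon. The same change has been seen once before, between compound 1 and compound 2, where it gave a 1.8-fold lower number from compound 1 to compound 2 (0.24 log units; within the scatter), a shift that stayed within the scatter. Because of a 1.8-fold lower number from compound 1 to compound 2 (0.24 log units; within the scatter) a small move toward a lower number is expected for compound 4, a 1.6-fold lower number from compound 3 to compound 4 (0.21 log units; within the scatter). Compound 4 is therefore estimated at 30 ug/mL, with a range from 15 ug/mL to 60 ug/mL.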

Compound 4, half-maximal cytotoxic concentration: 20.3 ug/mL
The estimate for compound 4 lay 1.5-fold (0.17 log units) above the measured number; measured number inside the range.
By their numbers in this assay, from the lowest: compound 4; then compounds 3, 2 and 1 (each within the scatter of the next, the first and the last beyond it).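

Chloro in place of hydrogen on the aromatic carbon now gives a 2.4-fold lower number from compound 3 to compound 4 (0.38 log units; beyond the scatter), so on this second core the step lies beyond the scatter, and it agrees with the earlier case: the same change on two cores in this assay, a 1.8-fold lower number (0.24 log units; within the scatter) from compound 1 to compound 2 and a 2.4-fold lower number (0.38 log units; beyond the scatter) from compound 3 to compound 4, 1.4-fold (0.13 log units) apart, within the scatter of two such steps. The ethyl change also keeps its direction with chloro already present, giving a 2.8-fold lower number from compound 2 to compound 4 (0.45 log units; beyond the scatter): the same change on two cores in this assay, a 2.1-fold lower number (0.32 log units; beyond the scatter) from compound 1 to compound 3 and a 2.8-fold lower number (0.45 log units; beyond the scatter) from compound 2 to compound 4, 1.4-fold (0.13 log units) apart, within the scatter of two such steps. Each change therefore moves the number the same way whether or not the other is present. Open, from the compounds shown here alone, is how fluoro or a carboxylic acid would behave on that aromatic carbon, and how a longer chain would behave on the saturated carbon.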